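Halogen swap on the benzyl ring of the sulfonamide series

The compounds below may be only part of what the source reports. "The series", "measured", "known", "first", "only" and "open" are said of these compounds alone.

Going by the values given here, in a functional assay on A2780 cells (Homo sapiens) for inhibition, read by MTT assay, with a stated time of 72 h (on this read-out higher numbers stand for weaker inhibition of growth and lower numbers for stronger inhibition of growth), compound 2 `O=S(=O)(NCCCNCc1ccc(Br)cc1)c1cc(C(F)(F)F)cc(C(F)(F)F)c1` gives 2600 nM, and compound 1 `O=S(=O)(NCCCNCc1ccc(Cl)c(Cl)c1)c1cc(C(F)(F)F)cc(C(F)(F)F)c1` sits within the scatter of it at 1500 nM; the step of a 1.7-fold higher number from compound 1 to compound 2 (0.24 log units; within the scatter) is the only measured comparison in the set. Compound 3 `O=S(=O)(NCCCNCc1ccc(Cl)cc1)c1cc(C(F)(F)F)cc(C(F)(F)F)c1` carries chloro in place of bromo on an aromatic carbon. Among the compounds with values here, the sole step that bears on this, the halogen change on the same ring from compound 1 to compound 2, stayed inside the scatter, so no step beyond the scatter in this assay is expected here either. Compound 3 is estimated at 3000 nM, range 1200 nM to 7500 nM, an expected step of a 1.2-fold higher number from compound 2 to compound 3 (0.06 log units; within the scatter).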

Compound 3, concentration for 50% growth inhibition: 1800 nM
Beside the measured number, compound 3's estimate is 1.7-fold (0.22 log units) above it; measured number inside the range.
By their numbers in this assay, from the lowest: compounds 1, 3 and 2 (each within the scatter of the next).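

In this assay, chloro in place of bromo on an aromatic carbon para to a large group gives a 1.4-fold lower number from compound 2 to compound 3 (0.16 log units; within the scatter), and hydrogen in place of chloro on the 3,4-dichlorophenyl ring gives a 1.2-fold higher number from compound 1 to compound 3 (0.08 log units; within the scatter). Both steps lie within the scatter, so the three halogen patterns on this ring are not told apart in this assay. No evidence on the cellular result is available to explain this. From the compounds shown here alone, whether a methoxy group or a nitrile at this place, or a longer chain between the two nitrogens, would give a step beyond the scatter stays open.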